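The source may hold more compounds than are shown below. What is called first, only, known or untested is meant among the compounds shown, and "the series" means these compounds.

Measured so far:
compound 1, `COc1ccc(-c2cc(OC)cc(C(=O)Nc3nn[nH]n3)n2)cc1`: 25%
compound 2, `CCCCc1ccc(-c2cc(OC)cc(C(=O)Nc3nn[nH]n3)n2)cc1`: 29%

Among the measured compounds shown here, both compounds have been tested in a functional assay on the whole organism for inhibition, with Rattus norvegicus as the target, at a dose of 1 mg/kg by the oral route; a lower number here means a weaker effect, a higher number a stronger effect of the compound at the dose given. Compound 1, `COc1ccc(-c2cc(OC)cc(C(=O)Nc3nn[nH]n3)n2)cc1`, gives 25% there, and compound 2, `CCCCc1ccc(-c2cc(OC)cc(C(=O)Nc3nn[nH]n3)n2)cc1`, gives 29%. For the measured compounds named here, the single step between them, a number 4 percentage points higher from compound 1 to compound 2 (within the scatter), lies within the scatter, so the two cannot be told apart on these numbers. Going by the values given here, compound 2 stands at one end of the two values, with compound 1 as its only neighbour and within the scatter of it.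

Compound 3, `COc1cc(C(=O)Nc2nn[nH]n2)nc(-c2ccc(C(C)(C)C)cc2)c1`, has not yet been measured. Its change from compound 2 is tert-butyl in place of butyl on an aromatic carbon. Among the compounds with values here, no measured step touches a change of this kind; the only step in hand, a number 4 percentage points higher from compound 1 to compound 2 (within the scatter), swaps methoxy for butyl at the same place and stays within the scatter. With nothing pointing either way, the step from compound 2 to compound 3 is expected to be no change at the digits printed from compound 2 to compound 3 (within the scatter), that is, none beyond the scatter. Compound 3 is therefore estimated to give 29% in this assay, within a range of 12% to 46%.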

Compound 3, a percentage reported as inhibition, in the whole organism at one dose (the size of the read-out at that dose, not a potency): 29%
For compound 3 middle estimate and measured number coincide at the digits printed; low and high end bracket the measured number.
By their numbers in this assay, from the lowest: compounds 1, 2 and 3 (each within the scatter of the next).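

In this assay, swapping butyl for tert-butyl on the aromatic carbon para to a large group, with the same atoms joined differently, gives no change at the digits printed from compound 2 to compound 3 (within the scatter) and so adds a branched group to the linear one as a second case that cannot be told apart from it. Against methoxy at the same place, tert-butyl gives a number 4 percentage points higher from compound 1 to compound 3 (within the scatter), so neither of the two four-carbon groups separates from methoxy, and all three compounds remain within the scatter of one another at this single dose. Nothing available bears on why these changes leave the read-out where it stands.

The compounds shown leave open whether any group at this place can move the read-out in this assay beyond the scatter, for instance an amine, a carboxylic acid or a longer chain such as octyl. On these data alone, all three also keep the amide and the methoxy group on the shared core, so the part these play in the effect at this dose remains open as well.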